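Series notes on one repeated side-chain change

The source may report more compounds than this note shows. Statements on the series, on what has been measured and on what is new or still open speak of the compounds shown alone.

Measured so far:
compound 1 `COc1cc2ncnc(N3CCc4ccccc43)c2cc1NC(=O)/C=C/CN1CCN(C)CC1`: 6430 nM
compound 2 `COc1cc2ncnc(N3CCc4ccccc43)c2cc1NC(=O)/C=C/CN1CCC(CO)CC1`: 2620 nM
compound 3 `CN1CCN(C/C=C/C(=O)Nc2cc3c(N4CCc5ccccc54)ncnc3cc2O[C@@H]2CCOC2)CC1`: 5350 nM

In a functional assay on MCF7 cells (Homo sapiens) for antiproliferative activity, read by MTT assay, with a stated time of 72 h (on this read-out lower numbers stand for stronger inhibition and higher numbers for weaker inhibition), compound 1 gives 6430 nM. The change 4-(hydroxymethyl)piperidin-1-yl in place of 4-methylpiperazin-1-yl on a saturated chain carbon bound to a double-bonded chain carbon brings a 2.5-fold lower number from compound 1 to compound 2 (0.39 log units; beyond the scatter). Compound 3 differs from compound 1 in the core by oxolan-3-yl in place of methyl on an oxygen on an aromatic ring, and in this assay a 1.2-fold lower number from compound 1 to compound 3 (0.08 log units; within the scatter). Compound 4 `O=C(/C=C/CN1CCC(CO)CC1)Nc1cc2c(N3CCc4ccccc43)ncnc2cc1O[C@@H]1CCOC1` is not yet measured; it carries the same change as compound 2, (4-(hydroxymethyl)piperidin-1-yl in place of 4-methylpiperazin-1-yl on a saturated chain carbon bound to a double-bonded chain carbon), made on the core of compound 3. The place is the same, so this is the same change seen once already. Within the data shown here, its only precedent is the step of a 2.5-fold lower number from compound 1 to compound 2 (0.39 log units; beyond the scatter), so a similar step is expected here, a 2.4-fold lower number from compound 3 to compound 4 (0.39 log units; beyond the scatter), resting on that single pair. Compound 4 is thus estimated at 2200 nM, with a range of 1000 nM to 5000 nM, because compound 3 stands at 5350 nM.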

Compound 4, half-maximal inhibitory concentration: 4690 nM
Beside the measured number, compound 4's estimate is 2.1-fold (0.33 log units) below it; measured number inside the range.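

In this assay, 4-(hydroxymethyl)piperidin-1-yl in place of 4-methylpiperazin-1-yl on the core of compound 3 gives a 1.1-fold lower number from compound 3 to compound 4 (0.06 log units; within the scatter), and this step does not separate from its earlier counterpart: the same change on two cores in this assay, a 2.5-fold lower number (0.39 log units; beyond the scatter) from compound 1 to compound 2 and a 1.1-fold lower number (0.06 log units; within the scatter) from compound 3 to compound 4, 2.2-fold (0.33 log units) apart, within the scatter of two such steps. Oxolan-3-yl in place of methyl, made with the 4-(hydroxymethyl)piperidin-1-yl side chain present, gives a 1.8-fold higher number from compound 2 to compound 4 (0.25 log units; within the scatter), and the two readings of that change do not separate either: the same change on two cores in this assay, a 1.2-fold lower number (0.08 log units; within the scatter) from compound 1 to compound 3 and a 1.8-fold higher number (0.25 log units; within the scatter) from compound 2 to compound 4, 2.2-fold (0.33 log units) apart, within the scatter of two such steps. The side-chain change is thus not shown to differ between the two cores, but equal transfer is not shown either, with one step beyond the scatter, one within it, and only two cores compared.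

Still open, as far as these compounds go, is how morpholin-4-yl or dimethylamino on the same chain carbon would behave on these two cores. Also open, from the compounds shown here alone, is whether ethyl in place of oxolan-3-yl on the aromatic oxygen would alter the side-chain step.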